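Methoxy for Fluoro on the Sulfonyl Aryl Ring

The source may report more compounds than this note shows. Statements on the series, on what has been measured and on what is new or still open speak of the compounds shown alone.

Measured so far:
compound 1, `COc1cc2c(Oc3ccc(NC(=O)/C=C/S(=O)(=O)c4ccccc4OC)cc3F)ccnc2cc1OCCCN1CCCCC1`, 980 nM
compound 2, `COc1cc2c(Oc3ccc(NC(=O)/C=C/S(=O)(=O)c4ccccc4F)cc3F)ccnc2cc1OCCCN1CCC(C)CC1`, 840 nM

In a functional assay on MKN-45 cells (Homo sapiens) for cytotoxicity, read by MTT assay, with a stated time of 72 h (a higher number here means a weaker inhibitor, a lower number a stronger inhibitor), compound 2 gives 840 nM, and compound 1 gives 980 nM. Compound 2 has the lowest of the two numbers, but its nearest neighbour, compound 1, lies within the scatter of this assay, so the two cannot be ranked against each other.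

The unmeasured compound 3, `COc1cc2c(Oc3ccc(NC(=O)/C=C/S(=O)(=O)c4ccccc4OC)cc3F)ccnc2cc1OCCCN1CCC(C)CC1`, differs from compound 2 in one place: methoxy in place of fluoro on an aromatic carbon. Within the data shown here, the same exchange at that position is already present in compound 1, though compound 1 also carries a different group at the far end of the molecule, so no single step between measured compounds isolates it.

Because compound 1 gives 980 nM and compound 2 gives 840 nM, both near each other, compound 3 is expected to stay close to compound 2, with a step of a 1.1-fold higher number from compound 2 to compound 3 (0.03 log units; within the scatter) that should not exceed the scatter in either direction. Compound 3 is thus estimated at 900 nM, in a range from 450 nM to 1800 nM.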

Compound 3, half-maximal inhibitory concentration: 2030 nM
Compound 3: the middle estimate sits 2.3-fold (0.35 log units) below what was measured, outside the stated range (above it).
By their numbers in this assay, from the lowest: compounds 2 and 1 (each within the scatter of the next); then compound 3.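

In this assay, the exchange of 2-fluorophenyl for 2-methoxyphenyl on the sulfonyl group now has a size of its own: the change gives a 2.4-fold higher number from compound 2 to compound 3 (0.38 log units; beyond the scatter) with the rest of the molecule held the same, a modest weakening that lies beyond the scatter. The far end of the molecule also proves not to be neutral, as methyl in place of hydrogen on a saturated ring carbon gives a 2.1-fold higher number from compound 1 to compound 3 (0.32 log units; beyond the scatter) with the 2-methoxyphenyl group held constant, again a modest step beyond the scatter, so that each of the two places counts in this assay when read from compound 3. Nothing available explains why either change raises the number.

The compounds shown leave open whether the weakening belongs to methoxy alone or would also appear with a longer ether such as ethoxy, or with a hydroxyl group or an amine on the same aromatic carbon. They also leave open whether the methyl step holds alongside 2-fluorophenyl, and how an ethyl group or a hydroxyl group would fare on that saturated ring carbon.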